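The source may hold more compounds than are shown below. What is called first, only, known or untested is meant among the compounds shown, and "the series" means these compounds.

Measured in an ADME assay on HeLa cells (Homo sapiens) for cytotoxicity, read by crystal violet staining, with a stated time of 72 h; on this read-out lower numbers stand for higher toxicity in this test and higher numbers for lower toxicity in this test:
- compound 1 `COC(=O)c1cc(CCCOc2c(C)cc(-c3noc(C(F)(F)F)n3)cc2C)on1`: 35400 nM
- compound 2 `Cc1cc(-c2noc(C(F)(F)F)n2)cc(C)c1OCCCc1cc(-c2ccc(OC(F)(F)F)cc2)no1`: > 100000 nM

Compound 2 gives > 100000 nM, which is a limit of the assay and not a number. Compound 3 `Cc1cc(-c2noc(C(F)(F)F)n2)cc(C)c1OCCCc1cc(C(=O)N(C)C)no1` departs from it at one place: dimethylcarbamoyl in place of 4-(trifluoromethoxy)phenyl on an aromatic carbon. Here dimethylcarbamoyl stands in place of 4-(trifluoromethoxy)phenyl on an aromatic carbon of a five-membered aromatic ring with 1 nitrogen and 1 oxygen.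

For the measured compounds named here, one measured step bears on this change: an at least 2.8-fold higher number from compound 1 to compound 2 (0.45 log units; beyond the scatter), where 4-(trifluoromethoxy)phenyl took the place of methoxycarbonyl on an aromatic carbon. Going by these compounds, that step is itself bounded by the limit, so its full size is unknown. Like methoxycarbonyl, dimethylcarbamoyl has no ring, so compound 3 is expected to fall back toward compound 1 at 35400 nM, though perhaps not all the way. The change is therefore expected to lower the number in this assay, and the expected step is an at least 1.8-fold lower number from compound 2 to compound 3 (0.25 log units; that floor lies within the scatter). Going by the values given here, with only one neighbour to go on, the estimate is wide, and a further limit remains possible. For compound 3 the estimated value is 55000 nM, with an expected range from 18000 nM to 100000 nM.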

Compound 3, half-maximal cytotoxic concentration: 13200 nM
Estimate against measurement, compound 3: 4.2-fold (0.62 log units) above; the whole stated range lies above it.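

Within this assay, dimethylcarbamoyl in place of 4-(trifluoromethoxy)phenyl on this aromatic carbon gives an at least 7.5-fold lower number from compound 2 to compound 3 (0.87 log units; beyond the scatter), so a group with no ring here can sit well below the ring-bearing compound. The change on the carbonyl carbon matters as well: dimethylamino in place of methoxy gives a 2.7-fold lower number from compound 1 to compound 3 (0.43 log units; beyond the scatter), so the two ringless groups, methoxycarbonyl and dimethylcarbamoyl, are told apart in this test, and compound 3 lies below compound 1 instead of between compound 1 and compound 2. The value of compound 2 is a limit and not a number, so the step down from it has a floor only: the limit of > 100000 nM in this assay, at which 1 of the 3 values shown sits.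

The three compounds leave open whether the lower number of compound 3 belongs to the amide carbonyl as such or to its two methyl groups, which a primary amide or a carboxylic acid at this position would help to separate. They also leave open whether the high number of compound 2 needs the trifluoromethoxy group or only the aromatic ring, a question that a plain phenyl at this position would address.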